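From Chloro to Methyl at the Edge of the Assay

The source may hold more compounds than are shown below. What is called first, only, known or untested is meant among the compounds shown, and "the series" means these compounds.

Compound 2 `CN1C(=O)C(O)(Cc2nnn[nH]2)c2cc(Cl)ccc21` sits at the edge of what a functional assay on MDA-MB-231 cells (Homo sapiens) for antiproliferative activity, read by MTT assay, with a stated time of 48 h (a higher number here means a weaker inhibitor, a lower number a stronger inhibitor), can read. Compound 2 gives > 100000 nM, which is a limit and not a number. Compound 1 `CN1C(=O)C(O)(Cc2nnn[nH]2)c2ccccc21` gives > 100000 nM, also a limit. This leaves little to work from, with the limit of > 100000 nM in this assay, at which 2 of the 3 values shown sit. For the measured compounds named here, compound 3 `CCN1C(=O)C(O)(Cc2nnn[nH]2)c2cc(Cl)ccc21` is the only one with a true number, as compound 3 gives 84900 nM in this assay.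

Compound 4 `Cc1ccc2c(c1)C(O)(Cc1nnn[nH]1)C(=O)N2C` differs from compound 2 by methyl in place of chloro on an aromatic carbon, which is methyl in place of chloro on an aromatic carbon. Going by the values given here, two measured steps bear on this change. Chloro in place of hydrogen on an aromatic carbon gave a step that the two limits leave unreadable from compound 1 to compound 2. Methyl in place of hydrogen on a saturated chain carbon gave an at least 1.1-fold lower number from compound 2 to compound 3 (0.07 log units; that floor lies within the scatter). Since neither shows a readable step beyond the scatter, no clear move in either direction is expected in this assay, and another limit is the likeliest report. The estimated step is a step that the limit leaves unreadable from compound 2 to compound 4. The estimate for compound 4 is 120000 nM, with an expected range of 60000 nM to 250000 nM.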

Compound 4, half-maximal inhibitory concentration: > 100000 nM
Compound 4: no number, only a limit; the forecaster's own chance of this, stated with the estimate: 75%; the middle value lies beyond the limit too.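

In this assay compound 4 gives > 100000 nM, which is a limit and not a number. Its steps from compound 1 and compound 2 cannot be read, because all three compounds stop at the same limit: the limit of > 100000 nM in this assay, at which 3 of the 4 values shown sit.

The compounds shown leave open how methyl, chloro and hydrogen on this aromatic carbon compare.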